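This account rests on a few compounds, and the source may have more. Where it says the series, first, only, none or still open, it means among the compounds named here.

Measured so far:
compound 1 `O=C(O)CCc1ccc(NC(=O)CC2OC(CO)C(O)C(O)C2O)cc1`, an assay on isolated protein for binding affinity to E-selectin (Homo sapiens) (a lower number here means a stronger inhibitor, a higher number a weaker inhibitor), 10000000 nM
compound 2 `NC(=O)CC[C@@H](NC(=O)CC1OC(CO)C(O)C(O)C1O)C(=O)O`, > 10000000 nM

Going by the values given here, compound 1 carries the only numeric value shown in this assay. For compound 2 the value is a limit of the assay, not a number, and one of the two values shown sits at it (the limit of > 10000000 nM in this assay, at which 1 of the 2 values shown sits). Compound 3 `O=C(O)CCCc1ccc(NC(=O)CC2OC(CO)C(O)C(O)C2O)cc1` differs from compound 1 by carboxymethyl in place of carboxy on a saturated chain carbon, two bonds along the chain from an aromatic carbon. Among the compounds with values here, no measured step between two compounds is available; the change no change at the digits printed from compound 1 to compound 3 (within the scatter) is expected to stay within the scatter, in no clear direction. Compound 3 is estimated at 10000000 nM, between 3000000 nM and 30000000 nM.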

Compound 3, half-maximal inhibitory concentration: > 10000000 nM
Compound 3 ended at the assay's limit (the forecaster's own chance of this, stated with the estimate: 50%); the middle value sits exactly at the limit.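

Compound 3 gives only a limit of the assay, not a number. In this assay, carboxymethyl in place of carboxy on a saturated chain carbon, two bonds along the chain from an aromatic carbon, gives a number no lower from compound 1 to compound 3 (the limit leaves the size open), so this first step at the position shows no gain from extending the chain. Most of the series now sits at the same ceiling: the limit of > 10000000 nM in this assay, at which 2 of the 3 values shown sit.

The size of the step cannot be read. As far as these compounds go, whether a shorter chain, or an amine in place of the carboxylic acid, would give a value clear of this limit remains open.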